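Mirror-image switch in a fluorinated phenylurea series

This account rests on a few compounds, and the source may have more. Where it says the series, first, only, none or still open, it means among the compounds named here.

Compound 1, `C[C@H](NC(=O)Nc1ccccc1F)c1ccccc1`, gives 92%.
Compound 2, `C[C@H](NC(=O)Nc1ccc(F)cc1)c1ccccc1`, gives 97%.
Compound 3, `C[C@@H](NC(=O)Nc1ccc(F)cc1F)c1ccccc1`, gives 100%.

In an ADME assay on the whole organism with Oryza sativa as the target, tested at 1 uM (a lower number here means a stronger effect, a higher number a weaker effect of the compound at the concentration tested), compound 3 shows the highest of the three numbers. Compound 2 stands nearest, with a value that differs from compound 3 within the scatter, and compound 1 stands furthest, also within the scatter. The three compounds therefore cannot be told apart on these numbers; all sit at the weak end of this assay.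

The next compound, compound 4, `C[C@H](NC(=O)Nc1ccc(F)cc1F)c1ccccc1`, has not been measured. Compared with compound 3 the change is the two compounds have the same atoms and bonds and differ only in configuration as drawn: 1 of 1 stereo elements differ; a stereocentre at a saturated chain carbon is drawn R in compound 3 and S in compound 4. Nothing leaves and nothing enters; only the drawn configuration at one saturated chain carbon is reversed.

Among the measured compounds shown here, no measured pair in this set differs in a single place, so the size of such a step is unknown here. With all three measured values crowded together at the top of the scale, the expected step from compound 3 to compound 4 is a number 5 percentage points lower from compound 3 to compound 4 (within the scatter), that is, none beyond the scatter. Compound 4 is therefore estimated at 95%, with a range from 80% to 100%.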

Compound 4, a percentage reported as activity, at one concentration (the size of the read-out at that concentration, not a potency): 100%
Beside the measured number, compound 4's estimate is 5 percentage points below it; measured number inside the range.
By their numbers in this assay, from the lowest: compounds 1, 2, 3 and 4 (each within the scatter of the next).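

In this assay, reversing the drawn configuration at the saturated chain carbon gives no change at the digits printed from compound 3 to compound 4 (within the scatter), so at this position the mirror-image switch leaves no visible mark on the read-out. What makes this pair a clean test is a single fact: the fact that compounds 3 and 4 differ only in the configuration as drawn. Fluoro in place of hydrogen on an aromatic carbon also stays inside the usual spread, with a number 3 percentage points higher from compound 2 to compound 4 (within the scatter) and a number 8 percentage points higher from compound 1 to compound 4 (within the scatter), so neither kind of change separates these compounds at the concentration tested.

All four compounds sit at the weak end of the scale, so these numbers cannot say whether mirror images would differ in a compound with a stronger effect. On these data alone, it also remains open whether a different group on an aromatic carbon, such as a methoxy group or an amine, or a longer chain on the saturated carbon, would bring the number down.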